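The source may report more compounds than this note shows. Statements on the series, on what has been measured and on what is new or still open speak of the compounds shown alone.

In a functional assay on L6 cells (Rattus norvegicus) for inhibition, read by scintillation counting, with a stated time of 3 h (a higher number here means a weaker inhibitor, a lower number a stronger inhibitor), compound 1 `COc1ccc(CNC(=O)c2nc(-c3ccc(F)cc3)n(CC[C@@H](O)C[C@@H](O)CC(=O)O)c2C2CC2)cc1F` gives 890 nM, compound 2 `O=C(O)C[C@H](O)C[C@H](O)CCn1c(-c2ccc(F)cc2)nc(C(=O)NCc2ccc(F)cc2)c1C1CC1` gives 1620 nM and compound 3 `Cc1ccc(CNC(=O)c2nn(-c3ccc(F)cc3)c(CC[C@@H](O)C[C@@H](O)CC(=O)O)c2C(C)C)cc1` gives 730 nM. Compound 2 cannot be told apart from compound 1, and its number stands above that of compound 3 by more than the scatter. Compound 3 differs from compound 2 in more than one place, so it offers no clean comparison here.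

Compound 4 `O=C(O)C[C@H](O)C[C@H](O)CCn1c(-c2ccc(F)cc2)nc(C(=O)NCc2ccccc2)c1C1CC1` is the next compound to read against compound 2. The change is hydrogen in place of fluoro on an aromatic carbon, para to a large group, which turns 4-fluorobenzyl into benzyl. Among the measured compounds shown here, no measured step shows the removal of this fluoro alone. For the measured compounds named here, the closest evidence is the one measured step on the same group, 4-fluorophenyl in place of 3-fluoro-4-methoxyphenyl, which is a 1.8-fold higher number from compound 1 to compound 2 (0.26 log units; within the scatter). That larger change to the group stayed within the scatter, so no step beyond the scatter is expected in this assay for the smaller change, and no direction can be argued. The expected step is a 1.1-fold lower number from compound 2 to compound 4 (0.03 log units; within the scatter). The estimate for compound 4 is 1500 nM, with an expected range from 700 nM to 3200 nM.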

Compound 4, half-maximal inhibitory concentration: 632 nM
The estimate for compound 4 lay 2.4-fold (0.38 log units) above the measured number; the whole stated range lies above it.
By their numbers in this assay, from the lowest: compounds 4, 3, 1 and 2 (each within the scatter of the next, the first and the last beyond it).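

In this assay, among the compounds shown here, the loss of the fluoro on an aromatic carbon, para to a large group, turning 4-fluorobenzyl into benzyl, gives a 2.6-fold lower number from compound 2 to compound 4 (0.41 log units; beyond the scatter) and is the first step on this group to pass the scatter, so this one fluorine matters here even though the step between the 3-fluoro-4-methoxyphenyl and 4-fluorophenyl ends did not pass it. The other new step, a 1.4-fold lower number from compound 1 to compound 4 (0.15 log units; within the scatter) for phenyl in place of 3-fluoro-4-methoxyphenyl, leaves those two compounds indistinguishable, so the three ends form no simple trend: compound 1 cannot be told apart from either compound 2 or compound 4, while those two differ clearly. Nothing measured alongside these numbers accounts for the effect of the fluoro.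

The compounds shown leave open whether a chloro, a methyl or a hydroxyl in place of this fluoro would give a number nearer to that of compound 2 or of compound 4. The step also rests on one matched pair, and whether it holds on the core of compound 3 remains to be seen.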